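The source may report more compounds than this note shows. Statements on the series, on what has been measured and on what is new or still open speak of the compounds shown alone.

In a functional assay on MCF7 cells (Homo sapiens) for antiproliferative activity, read by MTT assay, with a stated time of 24 h (a higher number here means a weaker inhibitor, a lower number a stronger inhibitor), compound 1 `CCn1c(C(=O)N[C@@H](C)C(=O)OC)ccc1C(CC)(CC)c1ccc(OCS(=O)(=O)c2ccccc2)c(C)c1` gives 43700 nM. Compound 2 `CCn1c(C(=O)NCCC(=O)O)ccc1C(CC)(CC)c1ccc(OCS(=O)(=O)c2ccccc2)c(C)c1` stands only at a limit of the assay, > 50000 nM. The change to compound 3 `CCn1c(C(=O)N[C@@H](CCC(=O)O)C(=O)O)ccc1C(CC)(CC)c1ccc(OCS(=O)(=O)c2ccccc2)c(C)c1` is 1,3-dicarboxypropyl in place of 2-carboxyethyl on an amide-type nitrogen. Among the compounds with values here, the one measured step that bears on it also falls on an amide-type nitrogen: an at least 1.1-fold higher number from compound 1 to compound 2 (0.05 log units; that floor lies within the scatter). Within the data shown here, with that step as the only guide, no shift beyond the scatter is expected in this assay, in either direction. The expected step is a step that the limit leaves unreadable from compound 2 to compound 3. For compound 3 the estimated value is 60000 nM, with an expected range of 25000 nM to 150000 nM.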

Compound 3, half-maximal inhibitory concentration: > 50000 nM
Compound 3 gave a limit, no number; the forecaster's own chance of this, stated with the estimate: 75%; the middle value is on the limit's open side.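

In this assay compound 3 is held at a limit, > 50000 nM, so 1,3-dicarboxypropyl on the amide-type nitrogen gives no number, just as 2-carboxyethyl gave none: the limit of > 50000 nM in this assay, at which 2 of the 3 values shown sit.

Within the data shown here, the step between compound 2 and compound 3 cannot be read, and the only readable step is an at least 1.1-fold higher number from compound 1 to compound 3 (0.05 log units; that floor lies within the scatter).

Left open is how far apart compound 2 and compound 3 lie beyond the limit. Also open, on these data alone, is whether an amine or a longer chain ending in a methyl ester on this nitrogen would give a measurable value.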